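Ring-methyl variant of the methyl-phenol amide

This account rests on a few compounds, and the source may have more. Where it says the series, first, only, none or still open, it means among the compounds named here.

The series holds two aryl cores carrying the same amide-linked chain to a fused saturated bicyclic amine. Compound 1 `Cc1ccc(O)c(C(=O)NCCCN2CCC[C@@H]3CCCC[C@@H]32)c1` bears a methyl on the aromatic ring, compound 2 `O=C(NCCCN1CCC[C@@H]2CCCC[C@@H]21)c1cc(Cl)ccc1O` a chloro; the difference between the two cores is methyl in place of chloro on an aromatic carbon. Compound 3 `CC1CC[C@@H]2CCCC[C@@H]2N1CCCNC(=O)c1cc(Cl)ccc1O` adds a methyl to the saturated ring of compound 2, and compound 4 `Cc1ccc(O)c(C(=O)NCCCN2CC(C)C[C@@H]3CCCC[C@@H]32)c1`, not yet measured, adds a methyl to the saturated ring of compound 1.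

In a functional assay on MDBK cells (Bos taurus) for cytotoxicity (on this read-out higher numbers stand for lower toxicity in this test and lower numbers for higher toxicity in this test), compound 1 gives only a limit, > 100 ug/mL. Compound 2 gives 43 ug/mL in this assay, and compound 3 gives 40 ug/mL. The aryl exchange gives an at least 2.3-fold lower number from compound 1 to compound 2 (0.36 log units; beyond the scatter). The ring methyl gives a 1.1-fold lower number from compound 2 to compound 3 (0.03 log units; within the scatter), so compound 2 and compound 3 read alike within the usual scatter.

The change from compound 1 to compound 4 is methyl in place of hydrogen on a saturated ring carbon; the change from compound 2 to compound 3 is methyl in place of hydrogen on a saturated ring carbon. These are the same kind of change but not the same: in compound 3 the methyl sits next to the ring nitrogen and next to the ring atom that bears a large group, whereas in compound 4 it sits two ring bonds from the ring nitrogen and two ring bonds from the ring atom that bears a large group.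

The expectation rests on compound 2 and compound 3, where the ring methyl gave a 1.1-fold lower number from compound 2 to compound 3 (0.03 log units; within the scatter), and on the limit of > 100 ug/mL in this assay, at which 1 of the 3 values shown sits, for compound 1. The step from compound 1 to compound 4 is therefore expected to be about a step that the limit leaves unreadable from compound 1 to compound 4 in this assay. Compound 4 is expected to give roughly 120 ug/mL in this assay, between 55 ug/mL and 300 ug/mL, most likely reported again as a limit.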

Compound 4, half-maximal cytotoxic concentration: 9.5 ug/mL
Compound 4: middle estimate off by 13-fold (1.10 log units), on the high side; measured number outside the range, below it.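

In this assay the methyl in place of hydrogen on a saturated ring carbon gives an at least 10-fold lower number from compound 1 to compound 4 (1.02 log units; beyond the scatter), so this kind of change does not carry over with the same size from one core to the other: the same change on two cores in this assay, a 1.1-fold lower number (0.03 log units; within the scatter) from compound 2 to compound 3 and an at least 10-fold lower number (1.02 log units; beyond the scatter) from compound 1 to compound 4, at least 9.7-fold (0.99 log units) apart, beyond the scatter of two such steps Compound 1 gives > 100 ug/mL, which is a limit: the limit of > 100 ug/mL in this assay, at which 1 of the 4 values shown sits. This does not show that the core alone sets the size of the step, since the methyl of compound 4 sits two ring bonds from the ring nitrogen and the methyl of compound 3 sits at a different ring carbon, so core and ring position change together across this single pair of steps.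

Open, as far as these compounds go, is how a methyl at the ring carbon used in compound 4 reads on the chloro core of compound 2, and how a methyl at the ring carbon used in compound 3 reads on the core of compound 1; those two results would separate the effect of the core from that of the position. Also open, from the compounds shown here alone, is whether an ethyl or a hydroxyl on the same saturated ring carbon, or a longer chain on the amide, would read like compound 4 in this assay.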